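The compounds below may be only part of what the source reports. "The series", "measured", "known", "first", "only" and "open" are said of these compounds alone.

Measured so far in a functional assay on the whole organism with Mus musculus as the target; a higher number here means that more compound is needed for the effect, a lower number that less compound is needed:
- compound 1 `CNC(=O)/C=C(\C)c1cccc(C(F)(F)F)c1`: > 100 mg/kg
- compound 2 `CNC(=O)/C(C)=C/c1cccc(C(F)(F)F)c1`: > 100 mg/kg
- compound 3 `CN(C)C(=O)CCC(=O)c1cccc(C(F)(F)F)c1`: > 50 mg/kg

In this assay compound 3 gives > 50 mg/kg, which is a limit and not a number. Among the compounds with values here, no compound has a number yet. The other two compounds stand at the limit of > 100 mg/kg in this assay, at which 2 of the 3 values shown sit.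

Compound 4 `CC(C)NC(=O)CCC(=O)c1cccc(C(F)(F)F)c1` is the next to read. It carries isopropylamino in place of dimethylamino on a carbonyl carbon.

Within the data shown here, no measured pair shows this change, so the expectation rests only on compound 3 and its limit of > 50 mg/kg. In this assay a small change is expected, with no firm direction and probably none beyond the scatter. The estimated step is a step that the limit leaves unreadable from compound 3 to compound 4.

Another reading that gives only a limit is quite likely. If a number is obtained, compound 4 is expected at 80 mg/kg, with an estimated range of 30 mg/kg to 200 mg/kg.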

Compound 4, dose for half-maximal effect: > 200 mg/kg
Compound 4: a limit, no number; the forecaster's own chance of this, stated with the estimate: 65%; middle value at least 2.5-fold (0.39 log units) from the limit.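

In this assay compound 4 gives > 200 mg/kg as a limit and not a number. Compound 3 also gives only a limit, > 50 mg/kg in the same assay. No step can be read between compound 3 and compound 4. The compounds shown leave open whether isopropylamino in place of dimethylamino changes the dose needed in this assay at all.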